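Removing One Methyl From a Fused Core

The compounds below may be only part of what the source reports. "The series", "measured", "known", "first", "only" and "open" are said of these compounds alone.

Of the compounds shown here, three that share a fused two-ring core have been tested in a functional assay for inhibition, with Homo sapiens as the target; on this read-out higher numbers stand for weaker inhibition and lower numbers for stronger inhibition. Compound 1 `CSc1nncc2c(C)nc(C)n12` gives only a limit of the assay, > 48000 nM. Compound 2 `CSc1nnc(C)c2c(C)nc(C)n12` likewise gives only a limit, > 48000 nM. Compound 3 `CCCc1nc(C)c2c(C)cnc(Nc3cc[nH]n3)n12` also gives only a limit, > 48000 nM. The change from compound 2 to compound 1 is hydrogen in place of methyl on an aromatic carbon, and its step is a step that the two limits leave unreadable from compound 2 to compound 1. How the core of compound 3 differs from that of compound 2 is not broken down here. Compound 4 `CCCc1ncc2c(C)cnc(Nc3cc[nH]n3)n12` is not yet measured; it arises from compound 3 by hydrogen in place of methyl on an aromatic carbon. This is the same kind of change as from compound 2 to compound 1, but the surroundings differ: in compound 2 the carbon lies in a six-membered aromatic ring with 3 nitrogen, ortho to a fused ring and para to a methylsulfanyl group, whereas in compound 3 it lies in a five-membered aromatic ring with 2 nitrogen, two ring bonds from the ring atom that bears a propyl group. Since all three measured values rest at the limit of > 48000 nM in this assay, at which 3 of the 3 values shown sit, the size of this change remains unreadable. The step from compound 3 to compound 4 in this assay is expected to be small, a step that the limit leaves unreadable from compound 3 to compound 4. Compound 4 is estimated at about 60000 nM, between 20000 nM and 200000 nM, most likely again only a limit.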

Compound 4, half-maximal inhibitory concentration: 39000 nM
Beside the measured number, compound 4's estimate is 1.5-fold (0.19 log units) above it; the range from low to high includes it.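

In this assay, replacing the methyl with hydrogen on the five-membered aromatic ring gives an at least 1.2-fold lower number from compound 3 to compound 4 (0.09 log units; that floor lies within the scatter), so the change may do very little or may do more, and this floor alone does not establish a real gain. From the compounds shown here alone, compound 3 gives > 48000 nM, which is a limit of the assay, so the true size of the step stays unknown, even though compound 4 has a measured number. The same change from compound 2 to compound 1 cannot be read, so the two cores cannot be compared and nothing shows that the change carries from one to the other, because the values of compounds 1, 2 and 3 are all limits: the limit of > 48000 nM in this assay, at which 3 of the 4 values shown sit.

The compounds shown leave open whether an amine or a methoxy group on that same aromatic carbon of compound 4 would give a clearly different number. They also leave open whether a longer chain in place of the propyl group would do so.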